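This account rests on a few compounds, and the source may have more. Where it says the series, first, only, none or still open, it means among the compounds named here.

Compound 1 `CN1CCN(c2nc(Oc3ccc(C#N)cn3)nc(-c3ccc(N4C(=O)CSC4c4ccccc4)cc3)n2)CC1` — "not determined" (no result reported)
Compound 2 `CN1CCN(c2nc(Oc3ccc(C#N)cn3)nc(-c3ccc(N4C(=O)CSC4c4ccc(O)cc4)cc3)n2)CC1` — > 62.5 ug/mL

In an ADME assay on Vero cells (Chlorocebus sabaeus) for cytotoxicity, read by MTT assay, with a stated time of 72 h (a lower number here means a stronger inhibitor, a higher number a weaker inhibitor), compound 1 carries no reported result, "not determined" (no result reported). In this assay compound 2 reaches only a limit of the assay rather than a number, > 62.5 ug/mL. That reading is the limit of > 62.5 ug/mL in this assay, at which 1 of the 2 values shown sits. Among the compounds with values here, no step between two measured compounds is available here, so compound 2 stands alone, at a limit. Compound 3 `COc1ccc(C2SCC(=O)N2c2ccc(-c3nc(Oc4ccc(C#N)cn4)nc(N4CCN(C)CC4)n3)cc2)cc1` differs from compound 2 by methyl in place of hydrogen on an oxygen on an aromatic ring. With nothing further to go on, no shift beyond the usual scatter is expected, and the step that the limit leaves unreadable from compound 2 to compound 3 is an expectation only. Compound 3 is therefore estimated at 80 ug/mL, between 35 ug/mL and 200 ug/mL, most likely again reported as a limit.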

Compound 3, half-maximal inhibitory concentration: > 62.5 ug/mL
Compound 3 ended at the assay's limit; the forecaster's own chance of this, stated with the estimate: 70%; the middle value is on the limit's open side.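

In this assay, within the data shown here, compound 2 and compound 3 both end at a limit rather than a number, and no step between them can be read. From the compounds shown here alone, whether 4-hydroxyphenyl to 4-methoxyphenyl changes cytotoxicity at all stays open.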